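Shortening the branched chain on compound 3's ring nitrogen

This account rests on a few compounds, and the source may have more. Where it says the series, first, only, none or still open, it means among the compounds named here.

Measured compounds:
- Compound 1 `CCSCCn1c(N2CCN(C)CC2)nc2ccccc21`: 19 nM
- Compound 2 `CCCSCn1c(N2CCN(C)CC2)nc2ccccc21`: 68 nM
- Compound 3 `CCCC(C)Cn1c(N2CCN(C)CC2)nc2ccccc21`: 500 nM

All three share one core and differ only in the chain on the ring nitrogen. In a functional assay on ileum for inhibition of histamine H1 receptor (Cavia porcellus) (on this read-out lower numbers stand for stronger inhibition and higher numbers for weaker inhibition), compound 3 gives the highest number of the three, with a 26-fold higher number from compound 1 to compound 3 (1.42 log units; beyond the scatter) and a 7.4-fold higher number from compound 2 to compound 3 (0.87 log units; beyond the scatter) both beyond the scatter, so its inhibition is the weakest on the evidence here.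

Compound 4 `CCCC(C)n1c(N2CCN(C)CC2)nc2ccccc21` takes one more step along the chain: 1-methylbutyl in place of 2-methylpentyl on an aromatic nitrogen. Within the data shown here, no measured step shows the same kind of change; the steps seen so far swap a sulfur-containing chain for an all-carbon one, and each time the all-carbon chain gave the higher number. Here both chains are all carbon and the chain merely loses one carbon, so those steps give little guidance and a step within the scatter, in either direction, is the most reasonable expectation.

Compound 4 is therefore estimated at 400 nM, with a range of 150 nM to 1200 nM, meaning an expected step of a 1.3-fold lower number from compound 3 to compound 4 (0.10 log units; within the scatter) in this assay.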

Compound 4, half-maximal inhibitory concentration: 1400 nM
For compound 4 the middle estimate is 3.5-fold (0.54 log units) below the measured one; the measured number lies above the stated range.
By their numbers in this assay, from the lowest: compound 1; then compound 2; then compound 3; then compound 4.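

The chain on the aromatic nitrogen still matters when no sulfur is involved: in this assay, replacing the 6-carbon 2-methylpentyl with the 5-carbon 1-methylbutyl gives a 2.8-fold higher number from compound 3 to compound 4 (0.45 log units; beyond the scatter) and so a step beyond the scatter between two all-carbon chains. Among these compounds, the earlier steps all involved a sulfur-containing chain, so this is the first sign that a small change in the length or branching of a purely carbon chain can weaken inhibition on its own. Compound 4 is now the weakest of the four, and its distance from the sulfur-containing chains has grown to a 21-fold higher number from compound 2 to compound 4 (1.31 log units; beyond the scatter) and a 74-fold higher number from compound 1 to compound 4 (1.87 log units; beyond the scatter) (a large step in both cases), but nothing available here on the properties of these compounds accounts for any of these differences.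

From the compounds shown here alone, what remains open is whether shortening the chain or moving the methyl branch drives the change, since the two happen together in this step, and an unbranched pentyl chain on the same nitrogen would help to separate them. Going by these compounds, it is also open whether the sulfur itself matters or any similar unbranched chain would do, a question that 2-ethoxyethyl, with oxygen in place of sulfur, could address.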